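The source may report more compounds than this note shows. Statements on the series, on what has been measured and on what is new or still open speak of the compounds shown alone.

Measured compounds:
Compound 1 `CC(C)(C)OC(=O)NC1CCCN(C(=O)CN2CN(c3ccccc3)C3(CCN(C(=O)c4ccc(C(C)(C)C)cc4)CC3)C2=O)C1`: 4200 nM
Compound 2 `CC1CCCN(C(=O)CN2CN(c3ccccc3)C3(CCN(C(=O)c4ccc(C5CCCCC5)cc4)CC3)C2=O)C1`: 3600 nM
Compound 3 `CC1CCCN(C(=O)CN2CN(c3ccccc3)C3(CCN(C(=O)c4ccc(C(C)(C)C)cc4)CC3)C2=O)C1`: 12000 nM

In an assay on HEK293 cells for displacement of a labelled ligand from NPC1-like intracellular cholesterol transporter 1 (Homo sapiens) (on this read-out lower numbers stand for stronger inhibition and higher numbers for weaker inhibition), compound 3 holds the highest of the three numbers, with a 2.9-fold higher number from compound 1 to compound 3 (0.46 log units; beyond the scatter) and a 3.3-fold higher number from compound 2 to compound 3 (0.52 log units; beyond the scatter) both beyond the scatter but modest. Compound 4 `CC(C)(C)c1ccc(C(=O)N2CCC3(CC2)C(=O)N(CC(=O)NCCCCN)CN3c2ccccc2)cc1` differs from compound 3 in one place: (4-aminobutyl)amino in place of 3-methylpiperidin-1-yl on a carbonyl carbon. Within the data shown here, only the step from compound 1 to compound 3 touches this region of the molecule, and it was modest; the step from compound 2 to compound 3 lies on the aromatic ring. Among the measured compounds shown here, no measured compound carries an open chain at this carbonyl carbon, so the direction is uncertain, with a modest move expected, leaning toward a lower number because a 2.9-fold higher number from compound 1 to compound 3 (0.46 log units; beyond the scatter) shows that changes in this region can help. For compound 4 the expected value is 7000 nM, within 1800 nM to 27000 nM, corresponding to an expected step of a 1.7-fold lower number from compound 3 to compound 4 (0.23 log units; within the scatter).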

Compound 4, half-maximal inhibitory concentration: 14500 nM
Estimate against measurement, compound 4: 2.1-fold (0.32 log units) below, within the range that was stated.
By their numbers in this assay, from the lowest: compounds 2 and 1 (each within the scatter of the next); then compounds 3 and 4 (each within the scatter of the next).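

In this assay, exchanging the ring of 3-methylpiperidin-1-yl for the open chain of (4-aminobutyl)amino on a carbonyl carbon gives a 1.2-fold higher number from compound 3 to compound 4 (0.08 log units; within the scatter), so this large change of shape and of hydrogen-bond donors leaves the number where it was. The earlier compounds had shown only a change on the ring, and this is the first open chain at this carbonyl carbon. Nothing available explains why the number holds.

From the compounds shown here alone, whether a carboxylic acid at the end of the chain, or a longer chain, would behave the same stays open. So does whether a morpholine on this carbonyl carbon would shift the number.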